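Amide aryl variation in the shared core series

The compounds below may be only part of what the source reports. "The series", "measured", "known", "first", "only" and "open" are said of these compounds alone.

Going by the values given here, compound 2 `Cc1ccccc1C(=O)Nc1cccc(-c2oc3cc(-c4ccc(F)cc4)ccc3c(=O)c2O)c1` gives 17600 nM in a functional assay on A549 cells (Homo sapiens) for antiproliferative activity, read by CCK-8 assay, with a stated time of 72 h (a lower number here means a stronger inhibitor, a higher number a weaker inhibitor), the higher of the two numbers so far; compound 1 `O=C(Nc1cccc(-c2oc3cc(-c4ccc(F)cc4)ccc3c(=O)c2O)c1)c1ccccc1F` gives 4410 nM. Among the compounds with values here, the single measured step, a 4.0-fold higher number from compound 1 to compound 2 (0.60 log units; beyond the scatter), shows that exchanging the group on the carbonyl carbon moves this assay beyond the scatter. Compound 3 `N#Cc1ccc(C(=O)Nc2cccc(-c3oc4cc(-c5ccc(F)cc5)ccc4c(=O)c3O)c2)cc1` differs from compound 2 by 4-cyanophenyl in place of 2-methylphenyl on a carbonyl carbon. Within the data shown here, no measured step covers this exchange directly, so its scale is taken from the step of a 4.0-fold higher number from compound 1 to compound 2 (0.60 log units; beyond the scatter). Compound 3 is expected to show a step of a 2.5-fold lower number from compound 2 to compound 3 (0.40 log units; beyond the scatter), toward a lower number. Compound 3 is estimated at 7000 nM, within 1800 nM to 28000 nM.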

Compound 3, half-maximal inhibitory concentration: 2360 nM
Estimate against measurement, compound 3: 3.0-fold (0.47 log units) above; the measured number falls inside the stated range.
By their numbers in this assay, from the lowest: compounds 3 and 1 (each within the scatter of the next); then compound 2.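

In this assay, 4-cyanophenyl on the carbonyl carbon gives a 7.5-fold lower number from compound 2 to compound 3 (0.87 log units; beyond the scatter), a step beyond the scatter, while a 1.9-fold lower number from compound 1 to compound 3 (0.27 log units; within the scatter) stays within it. At this position, 4-cyanophenyl and 2-fluorophenyl therefore cannot be told apart, and only 2-methylphenyl stands apart among the three groups. Nothing at hand accounts for this difference. Still open, going by these compounds, is whether 4-methylphenyl would read with 2-methylphenyl or with 4-cyanophenyl. Also open, on these data alone, is how an unsubstituted phenyl or a pyridine ring would read on the same carbonyl carbon.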